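The source may hold more compounds than are shown below. What is called first, only, known or untested is meant among the compounds shown, and "the series" means these compounds.

In a functional assay on MDA-MB-231 cells (Homo sapiens) for inhibition, read by CellTiter-Glo, with a stated time of 72 h (a higher number here means that more compound is tolerated, a lower number that less compound is tolerated), compound 1 `CC1=C(CC(=O)N(C)CCN(C)S(=O)(=O)c2ccccc2)c2cc(F)ccc2/C1=C\c1ccc([S+](C)[O-])cc1` gives 12200 nM, compound 2 `CC1=C(CC(=O)N(C)CCN(C)S(=O)(=O)c2cccc3ccccc23)c2cc(F)ccc2/C1=C\c1ccc([S+](C)[O-])cc1` gives 29100 nM and compound 3 `CC1=C(CC(=O)N(C)CCN(C)S(=O)(=O)c2ccc3ccccc3c2)c2cc(F)ccc2/C1=C\c1ccc([S+](C)[O-])cc1` gives 32100 nM. Compound 2 therefore sits level with compound 3, and both stand above compound 1. Naphthalen-1-yl in place of phenyl on the sulfonyl sulfur gave a 2.4-fold higher number from compound 1 to compound 2 (0.38 log units; beyond the scatter), naphthalen-2-yl gave a 2.6-fold higher number from compound 1 to compound 3 (0.42 log units; beyond the scatter), and swapping the two naphthalene groups gave a 1.1-fold higher number from compound 2 to compound 3 (0.04 log units; within the scatter). Compound 4 `CC1=C(CC(=O)N(C)CCN(C)S(=O)(=O)c2cccc3c(N(C)C)cccc23)c2cc(F)ccc2/C1=C\c1ccc([S+](C)[O-])cc1` differs from compound 2 by dimethylamino in place of hydrogen on an aromatic carbon. Within the data shown here, no measured compound carries this group, so these modest steps are the only guide, and no step beyond the scatter is expected in this assay. The expected change is a 1.2-fold lower number from compound 2 to compound 4 (0.07 log units; within the scatter). Compound 4 is estimated at 25000 nM, with an expected range of 10000 nM to 60000 nM.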

Compound 4, half-maximal cytotoxic concentration: > 50000 nM
Compound 4 ended at the assay's limit; the forecaster's own chance of this, stated with the estimate: 15%; middle value at least 2.0-fold (0.30 log units) away from the limit.
By their numbers in this assay, from the lowest: compound 1; then compounds 2 and 3 (each within the scatter of the next). At a limit, above all of these: compound 4.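

In this assay compound 4 gives > 50000 nM, which is a limit of the assay and not a number. Dimethylamino in place of hydrogen on this aromatic carbon gives an at least 1.7-fold higher number from compound 2 to compound 4 (0.23 log units; that floor lies within the scatter), so the true size of the step remains unknown. Among these compounds, still, this change on the naphthalen-1-yl group gives no sign of a lower number, which the earlier compounds could not show because none carries a group on that ring. Open, from the compounds shown here alone, is how a primary amine, a methoxy group or a carboxylic acid on the same aromatic carbon would read, and whether any would give a value short of the limit.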